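A few compounds are considered here, and "the series" means these few. Any claim that something is new, unique, unknown or untested is made for them only; others in the source may bear on it.

Going by the values given here, compound 3 `COc1ccc(C(=O)c2ccc3c(ccn3S(=O)(=O)c3cccc(/C=C/C(=O)NO)c3)c2)cc1OC` carries a 3,4-dimethoxyphenyl on the carbonyl carbon of the shared core; in an assay on isolated protein for inhibition of histone deacetylase 8 (Homo sapiens) (on this read-out lower numbers stand for stronger inhibition and higher numbers for weaker inhibition), compound 3 gives 1420 nM, the highest of the three numbers measured so far. Compound 1 `COc1cc(C(=O)c2ccc3c(ccn3S(=O)(=O)c3cccc(/C=C/C(=O)NO)c3)c2)cc(OC)c1OC` gives 1260 nM and compound 2 `COc1ccc(C(=O)c2ccc3c(ccn3S(=O)(=O)c3cccc(/C=C/C(=O)NO)c3)c2)cc1` gives 812 nM; the steps of a 1.1-fold higher number from compound 1 to compound 3 (0.05 log units; within the scatter) and a 1.7-fold higher number from compound 2 to compound 3 (0.24 log units; within the scatter) stay within the scatter, as does a 1.6-fold lower number from compound 1 to compound 2 (0.19 log units; within the scatter). Compound 4 `O=C(/C=C/c1cccc(S(=O)(=O)n2ccc3cc(C(=O)c4ccc(F)cc4)ccc32)c1)NO` differs from compound 3 by 4-fluorophenyl in place of 3,4-dimethoxyphenyl on a carbonyl carbon. The nearest guides are a 1.7-fold higher number from compound 2 to compound 3 (0.24 log units; within the scatter), read backwards, and a 1.6-fold lower number from compound 1 to compound 2 (0.19 log units; within the scatter), both within the scatter. Among the compounds with values here, with both methoxy groups gone and no measured step covering fluorine, only a small lowering is expected, a 1.6-fold lower number from compound 3 to compound 4 (0.20 log units; within the scatter), not beyond the scatter. For compound 4 the expected value is 900 nM, with a range from 400 nM to 2500 nM.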

Compound 4, half-maximal inhibitory concentration: 2750 nM
Estimate against measurement, compound 4: 3.1-fold (0.49 log units) below; measured number outside the range, above it.
By their numbers in this assay, from the lowest: compounds 2, 1, 3 and 4 (each within the scatter of the next, the first and the last beyond it).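

In this assay, going by these compounds alone, 4-fluorophenyl on the carbonyl carbon yields the first steps beyond the scatter, though modest ones (a 3.4-fold higher number from compound 2 to compound 4 (0.53 log units; beyond the scatter); a 2.2-fold higher number from compound 1 to compound 4 (0.34 log units; beyond the scatter)), while the step from the dimethoxy analogue stays within it (a 1.9-fold higher number from compound 3 to compound 4 (0.29 log units; within the scatter)). This position therefore does respond to the aryl group, which the methoxy-bearing compounds 1, 2 and 3 alone did not show. No evidence at hand accounts for this rise. Still open, going by these compounds, is whether the rise follows from the fluoro group itself or from the absence of methoxy. A plain phenyl or an aminophenyl on the carbonyl carbon would help separate the two.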